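Swapping a phenyl for a thiazole on a sulfonyl

A few compounds are considered here, and "the series" means these few. Any claim that something is new, unique, unknown or untested is made for them only; others in the source may bear on it.

Compound 1 `CCCCC(O)c1ccc(CN(CCCCCCC(=O)O)S(C)(=O)=O)cc1`: > 3200 nM
Compound 2 `CC(C)(C)c1ccc(CN(Cc2cccc(CCC(=O)O)c2)S(=O)(=O)c2ccccc2)cc1`: > 3200 nM
Compound 3 `CC(C)(C)c1ccc(CN(Cc2cccc(OCC(=O)O)c2)S(C)(=O)=O)cc1`: > 3200 nM

All three compounds were tested in an assay on HEK293 cells for inhibition of prostaglandin E2 receptor EP4 subtype (Rattus norvegicus); on this read-out higher numbers stand for weaker inhibition and lower numbers for stronger inhibition. None of them gave a number. Compound 2 reached only the reporting limit of this assay, > 3200 nM. Compound 1 likewise stopped at a limit, > 3200 nM. Compound 3 also stopped at a limit, > 3200 nM. In other words, every result so far sits at the limit of > 3200 nM in this assay, at which 3 of the 3 values shown sit, so compound 2 cannot be placed above or below the other two; all that is known is that it is a weak inhibitor, if it inhibits at all.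

For the measured compounds named here, compound 4 `CC(C)(C)c1ccc(CN(Cc2cccc(CCC(=O)O)c2)S(=O)(=O)c2nccs2)cc1` is the one change from compound 2 that has not yet been tested: 1,3-thiazol-2-yl in place of phenyl on a sulfonyl sulfur. Going by the values given here, since no pair of measured compounds differs in a single place, no measured step shows what such an exchange does in this assay. The change is small in size, and nothing measured points either way, so no shift beyond the usual scatter is expected from compound 2 to compound 4, that is a step that the limit leaves unreadable from compound 2 to compound 4. Compound 4 is therefore estimated at 3500 nM, with a range from 800 nM to 15000 nM, and it is quite likely that this assay will again report only a limit.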

Compound 4, half-maximal inhibitory concentration: > 3200 nM
Compound 4: a limit, no number (the forecaster's own chance of this, stated with the estimate: 65%); the middle value lies beyond the limit too.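

No step can be read from compound 2 to compound 4, since both results are limits of the assay and not numbers: the limit of > 3200 nM in this assay, at which 4 of the 4 values shown sit.

In this assay the compounds shown leave open whether 1,3-thiazol-2-yl in place of phenyl on a sulfonyl sulfur changes inhibition at all, and how strongly any of the four compounds inhibits.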